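Aryl swap on the shared core: notes toward compound 3

This account rests on a few compounds, and the source may have more. Where it says the series, first, only, none or still open, it means among the compounds named here.

Among the measured compounds shown here, compound 2 `Cc1ccccc1Nc1nc(SCc2ccc(C(F)(F)F)cc2)nc2ccccc12` is the only member of this pair that returns a number in a functional assay on MDA-MB-231 cells (Homo sapiens) for cytotoxicity, read by MTT assay, with a stated time of 72 h (on this read-out lower numbers stand for stronger inhibition and higher numbers for weaker inhibition), where compound 2 gives 27100 nM. Compound 1 `CCCCCCCCCCCCNc1nc(SCc2ccc(C(F)(F)F)cc2)nc2ccccc12` is reported in this assay only as a limit, giving > 50000 nM. For the measured compounds named here, the single point of evidence on the measured values is the limit of > 50000 nM in this assay, at which 1 of the 2 values shown sits. Going by the values given here, no step between two measured compounds is available, so nothing in the data speaks to the size or direction of a single change on the nitrogen. Compound 3 `COc1ccc(Nc2nc(SCc3ccc(C(F)(F)F)cc3)nc3ccccc23)cc1` differs from compound 2 by 4-methoxyphenyl in place of 2-methylphenyl on a nitrogen on an aromatic ring. In the absence of a measured step, the change from compound 2 to compound 3 in this assay is expected to be small, a 1.2-fold lower number from compound 2 to compound 3 (0.09 log units; within the scatter), and to lie within the usual scatter rather than beyond it. In this assay compound 3 is expected to give about 22000 nM, with a range from 7000 nM to 60000 nM. The chance that compound 3 returns only a limit, as compound 1 does, is not negligible.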

Compound 3, half-maximal inhibitory concentration: 15700 nM
Beside the measured number, compound 3's estimate is 1.4-fold (0.15 log units) above it, and the stated range covers the measured number.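

In this assay, among the compounds shown here, replacing 2-methylphenyl with 4-methoxyphenyl on a nitrogen on an aromatic ring gives the first step that can be read at this position: a 1.7-fold lower number from compound 2 to compound 3 (0.24 log units; within the scatter). Both aryl groups therefore return numbers on the shared core, and this swap, which adds one hydrogen-bond acceptor by the count, cannot be told apart from repeat-measurement variation. The data offer no cause for the size of this step.

Steps involving compound 1 cannot be read, since its entry is a limit and not a number: the limit of > 50000 nM in this assay, at which 1 of the 3 values shown sits. Whether a carboxylic acid or an amine on the aryl ring, or a shorter alkyl chain on the nitrogen, would move the number beyond the scatter remains open.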